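The compounds below may be only part of what the source reports. "The series", "measured", "known", "first", "only" and "open" are said of these compounds alone.

In a functional assay (muscle tissue) with Rattus norvegicus as the target (a lower number here means that less compound is needed, a higher number that more compound is needed for the effect), compound 1 `CNC(=O)C1=CC(C)(C)Oc2ccc([N+](=O)[O-])cc21` gives 10.7 nM and compound 2 `C#CCNC(=O)C1=CC(C)(C)Oc2ccc([N+](=O)[O-])cc21` gives 7.94 nM, so compound 2 stands level with compound 1, within the usual scatter. Compound 3 `CC1(C)C=C(C(=O)NCCO)c2cc([N+](=O)[O-])ccc2O1` keeps the shared core and differs from compound 2 only in the amide chain: hydroxymethyl in place of ethynyl on a saturated chain carbon bound to an amide-type nitrogen. In words, hydroxymethyl takes the place of ethynyl on a saturated chain carbon bound to an amide-type nitrogen. Among the measured compounds shown here, only one measured step bears on this change, and it sits at the same carbon: a 1.3-fold lower number from compound 1 to compound 2 (0.13 log units; within the scatter). For the measured compounds named here, that step brought in ethynyl, and no measured compound carries hydroxymethyl, so the data give only indirect guidance on the new group. A modest move towards a higher number is expected, with wide uncertainty. The expected size of the change is a 3.1-fold higher number from compound 2 to compound 3 (0.50 log units; beyond the scatter). The estimate for compound 3 is 25 nM, with an expected range from 7 nM to 90 nM.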

Compound 3, half-maximal effective concentration: 182 nM
Beside the measured number, compound 3's estimate is 7.3-fold (0.86 log units) below it, and the stated range ends below it.
By their numbers in this assay, from the lowest: compounds 2 and 1 (each within the scatter of the next); then compound 3.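

The earlier step, a 1.3-fold lower number from compound 1 to compound 2 (0.13 log units; within the scatter), lay within the scatter and left this place on the amide chain looking tolerant of change, but in this assay that picture no longer holds, with a 23-fold higher number from compound 2 to compound 3 (1.36 log units; beyond the scatter). The rise is also large when measured against the shorter chain, a 17-fold higher number from compound 1 to compound 3 (1.23 log units; beyond the scatter), so it does not depend on ethynyl as the point of comparison: among these compounds, only the 2-hydroxyethyl chain of compound 3 stands apart. Nothing available here explains the size of this rise.

The compounds shown leave open whether the rise follows the free hydroxyl group itself, which a 2-methoxyethyl chain would test. They also leave open whether a longer 3-hydroxypropyl chain or a terminal amine would behave like compound 3.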